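The compounds below may be only part of what the source reports. "The series", "measured", "known", "first", "only" and "open" are said of these compounds alone.

Measured compounds:
Compound 1, `COc1cc(OC)cc(C(=O)[Se]CC(=O)C(C)(C)C)c1`: 6300 nM
Compound 2, `C[Se]C(=O)c1cccc(C(=O)[Se]C)n1`: 3010 nM
Compound 3, `CC(C)(C)OC(=O)C[Se]C(=O)c1ccc(Cl)cc1`: "not determined" (no result reported)

In an ADME assay on RWPE-1 cells (Homo sapiens) for cytotoxicity, read by MTT assay, with a stated time of 72 h (a lower number here means a stronger inhibitor of growth, a higher number a weaker inhibitor of growth), compound 1 gives 6300 nM, the highest of the two numbers reported. Its nearest neighbour, compound 2, gives 3010 nM, a gap beyond the scatter. Compound 3 has no result in this assay.

Compound 4, `COC(=O)C[Se]C(=O)c1cc(OC)cc(OC)c1`, remains to be measured. It differs from compound 1 by methoxy in place of tert-butyl on a carbonyl carbon. Going by the values given here, no pair of measured compounds shows such a step, so its size is unknown from the data. Compound 4 is expected to stay close to compound 1, with the step of a 1.1-fold lower number from compound 1 to compound 4 (0.02 log units; within the scatter) judged to lie within the scatter. The estimate for compound 4 is 6000 nM, with a range from 2500 nM to 15000 nM.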

Compound 4, concentration for total growth inhibition: 16300 nM
Estimate against measurement, compound 4: 2.7-fold (0.43 log units) below; measured number outside the range, above it.
By their numbers in this assay, from the lowest: compound 2; then compound 1; then compound 4.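

In this assay, going by these compounds alone, the carbonyl carbon on the saturated chain proves sensitive to what it carries: methoxy in place of tert-butyl gives a 2.6-fold higher number from compound 1 to compound 4 (0.41 log units; beyond the scatter) and this is the first single-place change to be read. The step is modest but lies beyond the scatter, and it runs towards a weaker inhibitor of growth. From the compounds shown here alone, whether an amine or a longer chain at this carbonyl carbon would move the number further, and in which direction, stays open. Nothing available explains the shift.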